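Swapping fluoro for chloro on a sulfonamide-linked triazole series

The compounds below may be only part of what the source reports. "The series", "measured", "known", "first", "only" and "open" are said of these compounds alone.

Measured so far:
- compound 1 `O=c1[nH]cc(S(=O)(=O)Nc2cccc(-c3cn(-c4ccccc4F)nn3)c2)c(=O)[nH]1`, in an ADME assay on GES1 cells (Homo sapiens) for cytotoxicity, read by MTT assay, with a stated time of 24 h (a higher number here means that more compound is tolerated, a lower number that less compound is tolerated), compound 1 is reported as "not toxic" (no number reported)
- compound 2 `Cc1ccccc1-n1cc(-c2ccc(NS(=O)(=O)c3c[nH]c(=O)[nH]c3=O)cc2)nn1`, in this assay compound 2 is reported as "not toxic" (no number reported)
- compound 3 `O=c1[nH]cc(S(=O)(=O)Nc2ccc(-c3cn(-c4ccccc4F)nn3)cc2)c(=O)[nH]1`, in this assay compound 3 gives > 100000 nM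

Of the compounds shown here, three share the same core and have been tested in this assay. For compound 1 and compound 2 only the word, and no number, is given. For compound 3 the value is a limit of the assay, not a measured number: the cytotoxic concentration was not reached in the range tested, and this is the limit described by the limit of > 100000 nM in this assay, at which 1 of the 3 values shown sits. So compound 3 stands at the untested edge, alongside two entries that carry no number at all, and nothing distinguishes the three.

Compound 4 `O=c1[nH]cc(S(=O)(=O)Nc2ccc(-c3cn(-c4ccccc4Cl)nn3)cc2)c(=O)[nH]1` has not yet been tested. It differs from compound 3 by one change: chloro in place of fluoro on an aromatic carbon. Within the data shown here, no step between two measured compounds is available to show what such a swap does here, so the only anchor is the limit for compound 3.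

Given that anchor, compound 4 is expected to sit at or around the same limit, with the step from compound 3 to compound 4 expected to be a number no higher from compound 3 to compound 4 (the limit leaves the size open), that is, no change beyond the scatter in either direction. The estimate for compound 4 is therefore 100000 nM, with a range from 40000 nM to 250000 nM, and it is likely that the assay again reports only a limit rather than a number.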

Compound 4, half-maximal cytotoxic concentration: 16400 nM
Compound 4: the middle estimate sits 6.1-fold (0.79 log units) above what was measured; the measured number lies below the stated range.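

In this assay, among these compounds, replacing 2-fluorophenyl with 2-chlorophenyl gives an at least 6.0-fold lower number from compound 3 to compound 4 (0.78 log units; beyond the scatter), the only step in this set that can be read. It shows that this position on the aromatic ring, ortho to a large group, is not indifferent to what sits there: a single halogen swap is enough for the cells to tolerate less of the compound. The true size of the step remains unknown because the value for compound 3 is a limit and not a number: the limit of > 100000 nM in this assay, at which 1 of the 4 values shown sits.

On these data alone, whether tolerance would change in the same direction with a bromo or a methoxy group at this position remains open. The compounds shown also cannot tell whether the same swap would lower the number on the core of compound 1.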